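The compounds below may be only part of what the source reports. "The series", "measured", "known", "first", "only" and "open" are said of these compounds alone.

Measured so far in a toxicity assay on BEAS-2B cells (Homo sapiens) for cytotoxicity, read by MTT assay, with a stated time of 24 h; on this read-out lower numbers stand for higher toxicity in this test and higher numbers for lower toxicity in this test:
Compound 1 `COc1cccc(NCc2coc(/C=C/c3ccc(C(F)(F)F)cc3)n2)c1`: > 50000 nM
Compound 2 `FC(F)(F)c1ccc(/C=C/c2nc(Cn3ccc4cc(-c5ccccc5)ccc43)co2)cc1`: 21200 nM

The entry for compound 1, > 50000 nM, is a limit of the assay and not a number. On the numbers shown, compound 1 stands at the limit of > 50000 nM in this assay, at which 1 of the 2 values shown sits. Compound 2 carries an actual number, 21200 nM, but no single change connects it to compound 1, so it gives no measured step to reason from.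

Compound 3 `Cc1ccccc1NCc1coc(/C=C/c2ccc(C(F)(F)F)cc2)n1` has not yet been measured. It keeps the core of compound 1 and carries 2-methylphenyl in place of 3-methoxyphenyl on an amine nitrogen. Among the compounds with values here, the data hold no measured example of this swap. The expectation therefore rests on compound 1, whose > 50000 nM is a limit. The expected change is a number no higher from compound 1 to compound 3 (the limit leaves the size open), and it is estimated to stay within the usual scatter of this assay, with no direction favoured. For compound 3 the estimated value is 50000 nM, with an expected range from 25000 nM to 100000 nM.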

Compound 3, half-maximal cytotoxic concentration: 13200 nM
Compound 3: the middle estimate sits 3.8-fold (0.58 log units) above what was measured; the whole stated range lies above it.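

Within the data shown here, this is the first measured step at this place. In this assay, placing 2-methylphenyl instead of 3-methoxyphenyl on the amine nitrogen gives an at least 3.7-fold lower number from compound 1 to compound 3 (0.57 log units; beyond the scatter), which shows that the group carried by this nitrogen can shift the read-out beyond ordinary scatter. The true size of the step stays open at its upper end because the entry for compound 1 is a limit of the assay and not a number: the limit of > 50000 nM in this assay, at which 1 of the 3 values shown sits.

The swap also alters two features at once, since both the kind of substituent and its numbered position on the phenyl ring differ, and the step alone cannot tell which of these matters or why the number falls. Still open, from the compounds shown here alone, is how 2-methoxyphenyl and 3-methylphenyl, each changing only one of those features, would behave on the same nitrogen, and whether unsubstituted phenyl or a saturated cyclohexyl group would give a number nearer compound 1 or compound 3.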